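Compound 2 to compound 4: removing the fluoro

The compounds below may be only part of what the source reports. "The series", "measured", "known", "first", "only" and "open" are said of these compounds alone.

In an ADME assay on microsomes from liver (Homo sapiens) for metabolic stability, read by LC-MS, using NADPH, with a stated time of 30 min, tested at 1 uM (on this read-out lower numbers stand for a less stable compound and higher numbers for a more stable compound), compound 2 `C=CC(=O)Nc1cc(Nc2ncc(F)c(Nc3ccccc3S(=O)(=O)N(C)C)n2)c(OC)cc1N(C)CCN(C)C` gives 9% at the low end of the three numbers. Compound 1 `C=CC(=O)Nc1cc(Nc2ncc(I)c(Nc3ccccc3S(=O)(=O)N(C)C)n2)c(OC)cc1N(C)CCN(C)C` gives 13% within the scatter of it, and compound 3 `C=CC(=O)Nc1cc(Nc2ncc(F)c(Nc3ccccc3S(=O)(=O)C(C)C)n2)c(OC)cc1N(C)CCN(C)C` gives 26% clearly above it. Compound 4 `C=CC(=O)Nc1cc(Nc2nccc(Nc3ccccc3S(=O)(=O)N(C)C)n2)c(OC)cc1N(C)CCN(C)C` carries the change hydrogen in place of fluoro on an aromatic carbon on the shared core, hydrogen in place of fluoro on an aromatic carbon. Within the data shown here, the nearest precedent, fluoro in place of iodo on an aromatic carbon, gave a number 4 percentage points lower from compound 1 to compound 2 (within the scatter) on this read-out. Isopropyl in place of dimethylamino on a sulfonyl sulfur gave a number 17 percentage points higher from compound 2 to compound 3 (beyond the scatter) but is a different kind of change and bears little here. No step beyond the scatter is therefore expected, the estimated move being a number 2 percentage points higher from compound 2 to compound 4 (within the scatter) with no firm direction. Compound 4 is expected at 11% within an estimated range of 4% to 22% for this compound.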

Compound 4, percent of the compound remaining: 10%
For compound 4 the middle estimate is 1 percentage points above the measured one; the range from low to high includes it.
By their numbers in this assay, from the lowest: compounds 2, 4 and 1 (each within the scatter of the next); then compound 3.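

Hydrogen in place of fluoro gives a number 1 percentage points higher from compound 2 to compound 4 (within the scatter) and hydrogen in place of iodo gives a number 3 percentage points lower from compound 1 to compound 4 (within the scatter) in this assay on the shared core. With dimethylamino on the sulfonyl sulfur, this position therefore shows no read-out difference beyond the scatter among iodo, fluoro and hydrogen in compound 1, compound 2 and compound 4. No measurement available here explains this result.

Open, going by these compounds, is whether a nitrile or an amine at this position would shift the number. Also open, on these data alone, is whether hydrogen in place of fluoro behaves alike with isopropyl on the sulfonyl sulfur, as in compound 3.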